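Fluorine count on the chain: from methyl to fluoromethyl

A few compounds are considered here, and "the series" means these few. Any claim that something is new, unique, unknown or untested is made for them only; others in the source may bear on it.

Measured so far:
compound 1, `O=C(/C=C/C(F)(F)F)Nc1ccccc1`: 0.267 h
compound 2, `C/C=C/C(=O)Nc1ccccc1`: > 8.53 h

The value shown for compound 2 is a limit of the assay, not a number. Compound 2 sits at the limit of > 8.53 h in this assay, at which 1 of the 2 values shown sits, the upper edge of what the two measured values show. Going by the values given here, the one measured step is an at least 31-fold higher number from compound 1 to compound 2 (1.50 log units; beyond the scatter); only a limit is known at its end, so its full size is open.

Compound 3, `O=C(/C=C/CF)Nc1ccccc1`, differs from compound 2 by fluoro in place of hydrogen on a saturated chain carbon bound to a double-bonded chain carbon. The change runs part of the way back along the same line as the measured step, which removed three fluorines at once, here a single fluorine enters on the saturated chain carbon. A fall in an ADME assay for pharmacokinetics, read by LC-MS, in phosphate buffer, with a stated time of 120 min, at pH 7.4, tested at 1 uM, in the presence of a further agent that is not named here (a lower number here means that the compound disappears faster, a higher number that the compound lasts longer), is therefore expected for compound 3, smaller than the measured step but likely beyond the scatter. Compound 3 is expected to give about 4 h in this assay, with a range from 1 h to 12 h. The expected step is an at least 2.1-fold lower number from compound 2 to compound 3 (0.32 log units; beyond the scatter); a limit rather than a number remains a fair possibility.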

Compound 3, half-life: > 8.53 h
Compound 3 gave a limit, no number (the forecaster's own chance of this, stated with the estimate: 30%); middle value at least 2.1-fold (0.32 log units) from the limit.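

Working notes: in this assay, one fluorine on the saturated chain carbon bound to a double-bonded chain carbon does not bring compound 3 down toward compound 1, and compound 3 stays at a limit of the assay rather than a number: the limit of > 8.53 h in this assay, at which 2 of the 3 values shown sit.

The short half-life of compound 1 therefore does not extend to every fluorinated chain in this position: fluoromethyl in place of trifluoromethyl gives an at least 31-fold higher number from compound 1 to compound 3 (1.50 log units; beyond the scatter), which matches an at least 31-fold higher number from compound 1 to compound 2 (1.50 log units; beyond the scatter) as printed, and both steps end on a limit, so their full size is open. The step between compound 2 and compound 3 cannot be read, since both of its ends are limits, and any difference between methyl and fluoromethyl stays hidden in this assay.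

The compounds shown leave open where between fluoromethyl and trifluoromethyl the half-life falls, a question that difluoromethyl on the same carbon would address. They also leave open how a longer chain or a nitrile at this position would behave, and whether any chain of this kind reaches a measurable half-life between the value of compound 1 and the limit.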